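A few compounds are considered here, and "the series" means these few. Any claim that something is new, unique, unknown or untested is made for them only; others in the source may bear on it.

Measured compounds:
- compound 1 `CC(C)Oc1cccc(-c2ccc(C(=O)N(Cc3cccc(OCCCCCC(=O)O)c3)C(C)C)cc2)c1`: > 26000 nM
- compound 2 `CC(C)N(Cc1cccc(OCCCCCC(=O)O)c1)C(=O)c1ccc(-c2cccc(OC(F)(F)F)c2)cc1`: > 26000 nM
- compound 3 `CC(C)N(Cc1cccc(OCCCCCC(=O)O)c1)C(=O)c1ccc(-c2cccc(F)c2)cc1`: > 26000 nM

In an ADME assay on HEK293 cells (Homo sapiens) for cytotoxicity, read by CellTiter-Glo and resazurin assay, with a stated time of 72 h (a higher number here means that more compound is needed for the effect, a lower number that less compound is needed), compound 1 reaches only the limit of the assay, > 26000 nM, so no number is known for it. Compound 2 likewise stops at a limit, > 26000 nM. Compound 3 also stops at a limit, > 26000 nM. Every one of the three values sits at the limit of > 26000 nM in this assay, at which 3 of the 3 values shown sit, which is why the steps between them cannot be sized: a step that the two limits leave unreadable from compound 1 to compound 2, a step that the two limits leave unreadable from compound 1 to compound 3 and a step that the two limits leave unreadable from compound 2 to compound 3.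

Compound 4 `CC(C)N(Cc1cccc(OCCCCCC(=O)O)c1)C(=O)c1ccc(-c2cccc(C(F)(F)F)c2)cc1` has not yet been measured in this assay. It differs from compound 1 in one place: trifluoromethyl in place of isopropoxy on an aromatic carbon. Within the data shown here, the steps that bear on this change are those from compound 1 to compound 2 and from compound 1 to compound 3, since each also replaces the isopropoxy group on the same aromatic carbon; both are unreadable, yet in each case the new compound again stayed at the limit.

For compound 4 the expectation is therefore no step beyond the scatter, most likely another limit, written as a step that the limit leaves unreadable from compound 1 to compound 4. The estimate for compound 4 in this assay is 40000 nM, within a range from 20000 nM to 120000 nM.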

Compound 4, half-maximal effective concentration: > 26000 nM
Compound 4 gave a limit, no number (the forecaster's own chance of this, stated with the estimate: 85%); the middle value does not contradict the limit.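

In this assay compound 4 gives > 26000 nM, which is a limit and not a number. Its steps to compound 1, compound 2 and compound 3 cannot be read, because every value shown is such a limit: the limit of > 26000 nM in this assay, at which 4 of the 4 values shown sit. The compounds shown leave open at what concentration any of these four compounds would reach the half-maximal effect on these cells.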